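A few compounds are considered here, and "the series" means these few. Any claim that something is new, unique, unknown or untested is made for them only; others in the source may bear on it.

Compound 1, `CCCCCCCCSc1nc(N)nc2c1ncn2/C=C1/CC1(CO)CO`: in an ADME assay on BCBL1 cells (Homo sapiens) for cytotoxicity, with a stated time of 7 days (on this read-out lower numbers stand for higher toxicity in this test and higher numbers for lower toxicity in this test), compound 1 gives > 20000 nM, which is a limit of the assay.
Compound 2, `CCCCCCSc1nc(N)nc2c1ncn2/C=C1/CC1(CO)CO`: compound 2 gives > 20000 nM, also a limit of the assay.
Compound 3, `CCCCCCOc1nc(N)nc2c1ncn2/C=C1/CC1(CO)CO`: compound 3 gives > 20000 nM, again a limit of the assay.

All three values sit at the limit of > 20000 nM in this assay, at which 3 of the 3 values shown sit, so the step from compound 1 to compound 2 cannot be sized: a step that the two limits leave unreadable from compound 1 to compound 2, made by hydrogen in place of ethyl on a saturated chain carbon, six bonds along the chain from a sulfur. The cores of compound 1 and compound 3 differ by hexyloxy in place of octylsulfanyl on an aromatic carbon.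

Compound 4, `CCCCOc1nc(N)nc2c1ncn2/C=C1/CC1(CO)CO`, has not yet been measured. It differs from compound 3 by hydrogen in place of ethyl on a saturated chain carbon, four bonds along the chain from an oxygen on an aromatic ring. Among the compounds with values here, this is the same kind of change as the one from compound 1 to compound 2, though there the chain carbon sits six bonds along the chain from a sulfur and here four bonds along the chain from an oxygen on an aromatic ring. With the earlier step unreadable, the expectation rests only on all three measured compounds sitting at the limit of > 20000 nM in this assay, at which 3 of the 3 values shown sit. Compound 4 is expected to sit at that limit as well, an expected step that the limit leaves unreadable from compound 3 to compound 4. The estimate for compound 4 is 30000 nM, expected to lie between 15000 nM and 80000 nM.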

Compound 4, half-maximal cytotoxic concentration: > 20000 nM
Compound 4: a limit, no number (the forecaster's own chance of this, stated with the estimate: 85%); the middle value is on the limit's open side.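

Compound 4 gives a limit of the assay, not a number, so its steps from compound 1, compound 2 and compound 3 cannot be read: the limit of > 20000 nM in this assay, at which 4 of the 4 values shown sit. The compounds shown leave open whether these four chains differ at all in this assay.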